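The source may hold more compounds than are shown below. What is called first, only, known or untested is meant among the compounds shown, and "the series" means these compounds.

Of the compounds shown here, three built on one shared core have been tested in a functional assay on HeLa cells (Homo sapiens) for antiproliferative activity, with a stated time of 24 h (a higher number here means a weaker inhibitor, a lower number a stronger inhibitor), and all three are weak inhibitors. Compound 1 `NC(=O)c1c(NC(=O)c2ccc(C(F)(F)F)cc2)sc2c1CCN(Cc1ccc(Cl)cc1)C2` reaches only a limit of the assay, > 50000 nM, and gives no number. Compound 2 `NC(=O)c1c(NC(=O)c2ccccc2F)sc2c1CCN(Cc1c(Cl)cccc1Cl)C2` gives 33000 nM. Compound 3 `NC(=O)c1c(NC(=O)c2ccccc2Cl)sc2c1CCN(C(=S)Nc1cccc3ccccc13)C2` gives 30800 nM, and its value and that of compound 2 lie within the usual scatter of each other, so neither stands apart from the other.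

Compound 4 `NC(=O)c1c(NC(=O)c2ccccc2Cl)sc2c1CCN(C(=S)Nc1c(Cl)cccc1Cl)C2` has not yet been measured. It differs from compound 3 in a single place: 2,6-dichlorophenyl in place of naphthalen-1-yl on an amide-type nitrogen. Going by the values given here, no pair of measured compounds that differ in one place is available, so the size of this step cannot be read from the data; the expected step is a small one, in no clear direction and not beyond the scatter. Compound 2 also carries a 2,6-dichlorophenyl group and gives 33000 nM, a weak value, which supports expecting compound 4 to remain weak. Compound 4 is therefore estimated at 35000 nM, with a range from 12000 nM to 100000 nM, and the expected step of a 1.1-fold higher number from compound 3 to compound 4 (0.06 log units; within the scatter) stays within the scatter.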

Compound 4, half-maximal inhibitory concentration: 26500 nM
For compound 4 the middle estimate is 1.3-fold (0.12 log units) above the measured one, within the range that was stated.
By their numbers in this assay, from the lowest: compounds 4, 3 and 2 (each within the scatter of the next). At a limit, above all of these: compound 1.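

Going by these compounds alone, this gives the first step in this assay that can be read between two compounds differing in one place, and it is a 1.2-fold lower number from compound 3 to compound 4 (0.07 log units; within the scatter). On the amide-type nitrogen whose other neighbour is the thiocarbonyl carbon, naphthalen-1-yl, with two aromatic rings of carbon only, and 2,6-dichlorophenyl, with one ring and two chlorine atoms, therefore cannot be told apart in this assay. Both compounds remain weak inhibitors, so this exchange of one aromatic group for another does not lift the series out of the weak range.

Going by these compounds, whether a pyridine ring, a carboxylic acid or a short alkyl chain at this place would move the number beyond the scatter stays open. The top of the scale also offers no number to compare with, only a limit: the limit of > 50000 nM in this assay, at which 1 of the 4 values shown sits.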